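Two Esters with Flat Inhibition, and a Third to Measure

A few compounds are considered here, and "the series" means these few. Any claim that something is new, unique, unknown or untested is made for them only; others in the source may bear on it.

Measured compounds:
compound 1 `CC1=C(C(=O)OCC2CC2)C(c2cccs2)NC(=O)N1` — 1%
compound 2 `CC1=C(C(=O)OC2CCCCC2)C(c2ccsc2)NC(=O)N1` — 1%

In an assay on membranes from HeLa cells for displacement of a labelled ligand from adenosine receptor A3 (Homo sapiens), read by scintillation counting, with a stated time of 180 min, tested at 1 uM (a lower number here means less inhibition, a higher number more inhibition at the concentration tested (going by the name of the read-out)), compound 1 gives 1% and compound 2 gives 1%. Compound 2 stands level with compound 1 at the digits shown, the two values lying within the scatter of each other. Compound 3 `CC1=C(C(=O)OCC2CC2)C(c2ccsc2)NC(=O)N1` differs from compound 2 by cyclopropylmethyl in place of cyclohexyl on an oxygen next to a carbonyl group. For the measured compounds named here, no step between measured compounds bears on this change, so nothing in the data points to a shift in either direction; the expectation is a step of no size beyond the scatter, a number 1 percentage points higher from compound 2 to compound 3 (within the scatter). Compound 3 is therefore estimated at 2%, within a range from -8% to 12%.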

Compound 3, a percentage reported as inhibition, at one concentration (the size of the read-out at that concentration, not a potency): 3%
Estimate against measurement, compound 3: 1 percentage points below; the range from low to high includes it.
By their numbers in this assay, from the lowest: compounds 1, 2 and 3 (each within the scatter of the next).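

In this assay, cyclopropylmethyl in place of cyclohexyl on an oxygen next to a carbonyl group reads as a number 2 percentage points higher from compound 2 to compound 3 (within the scatter), and thiophen-3-yl in place of thiophen-2-yl on a saturated ring carbon reads as a number 2 percentage points higher from compound 1 to compound 3 (within the scatter). For the compounds shown here, these are the first single changes that can be read here, and neither separates the compounds at the concentration tested. No supporting measurement bears on this result.

As far as these compounds go, it remains open whether a longer chain or an amine on an oxygen next to a carbonyl group would give a value beyond the scatter of these three.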